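A few compounds are considered here, and "the series" means these few. Any claim that something is new, unique, unknown or untested is made for them only; others in the source may bear on it.

In an ADME assay on microsomes from liver (Rattus norvegicus) for metabolic stability, with a stated time of 10 min (a lower number here means that less of the compound is left, a higher number that more of the compound is left), compound 2 `Cc1cc(C)c(Nc2nc(Cl)cn([C@H](C)C3CC3)c2=O)c(C)n1` gives 87% and compound 1 `COc1cc(C)c(Nc2nc(Cl)cn([C@H](C)C3CC3)c2=O)c(C)n1` gives 79%, two numbers within the usual scatter of each other. The next structure, compound 3 `Cc1cc(OC(F)F)nc(C)c1Nc1nc(Cl)cn([C@H](C)C2CC2)c1=O`, is still unmeasured and carries the change (difluoromethoxy in place of methyl on an aromatic carbon), which puts difluoromethoxy in place of methyl on an aromatic carbon. Among the measured compounds shown here, the one measured step that bears on this, a number 8 percentage points higher from compound 1 to compound 2 (within the scatter), is methyl in place of methoxy, and it stays within the scatter. Difluoromethoxy itself is untested here, so only a modest change is expected, with an estimated a number 7 percentage points lower from compound 2 to compound 3 (within the scatter). The estimate for compound 3 is 80%, with an expected range from 62% to 93%.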

Compound 3, percent of the compound remaining: 89%
Estimate against measurement, compound 3: 9 percentage points below; the measured number falls inside the stated range.
By their numbers in this assay, from the lowest: compounds 1, 2 and 3 (each within the scatter of the next).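

At this position, next to the ring nitrogen and para to a large group, difluoromethoxy in place of methyl gives a number 2 percentage points higher from compound 2 to compound 3 (within the scatter) in this assay and so stays within the scatter. Putting difluoromethyl in place of methyl on the oxygen gives a number 10 percentage points higher from compound 1 to compound 3 (within the scatter) and also stays within the scatter, so methyl, methoxy and difluoromethoxy cannot be told apart here. Nothing available explains why these numbers lie so close. Still open, as far as these compounds go, is whether an amine or a carboxylic acid at this position would stay within the scatter too.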